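Aryl swap on the amide nitrogen of compound 1

The source may report more compounds than this note shows. Statements on the series, on what has been measured and on what is new or still open speak of the compounds shown alone.

- compound 1 `COc1ccc(NC(=O)CN2CCN(c3nnc(Cc4ccncc4)c4ccccc34)CC2)cc1OC`: 100 nM
- compound 2 `O=C(CN1CCN(c2nnc(Cc3ccccc3)c3ccccc23)CC1)Nc1ccc(F)c(C(F)(F)F)c1`: 760 nM
- compound 3 `Cc1ccccc1NC(=O)CN1CCN(c2nnc(Cc3ccccc3)c3ccccc23)CC1`: 17300 nM

All three values come from a functional assay on MDA-MB-231 cells (Homo sapiens) for cytotoxicity, read by MTT assay, with a stated time of 72 h; a lower number here means a stronger inhibitor, a higher number a weaker inhibitor. Compound 1 has the lowest number of the three, clear of both others. Next in line is compound 4 `O=C(CN1CCN(c2nnc(Cc3ccncc3)c3ccccc23)CC1)Nc1ccc(F)c(Cl)c1`, which keeps the core of compound 1 and changes one group on an amide-type nitrogen: 3-chloro-4-fluorophenyl in place of 3,4-dimethoxyphenyl on an amide-type nitrogen. In words, 3-chloro-4-fluorophenyl stands in place of 3,4-dimethoxyphenyl.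

For the measured compounds named here, the only measured step at this place is a 23-fold higher number from compound 2 to compound 3 (1.36 log units; beyond the scatter). It shows that the group on this nitrogen can move the number strongly, but it involves other groups on a different core, so it does not fix the size here. The closest entering group is the 4-fluoro-3-(trifluoromethyl)phenyl of compound 2, which reads 760 nM on its own core. Going by the values given here, no measured pair separates the core from the amide group, so that value serves only as a loose upper guide.

A moderate move to a higher number is expected, estimated as a 2.5-fold higher number from compound 1 to compound 4 (0.40 log units; beyond the scatter). For compound 4 the expected value in this assay is 250 nM, with an estimated range of 60 nM to 1100 nM.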

Compound 4, half-maximal inhibitory concentration: 4 nM
The estimate for compound 4 lay 63-fold (1.80 log units) above the measured number, and the stated range ends above it.
By their numbers in this assay, from the lowest: compound 4; then compound 1; then compound 2; then compound 3.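

For the compounds shown here, on the core of compound 1, 3-chloro-4-fluorophenyl in place of 3,4-dimethoxyphenyl on the amide-type nitrogen gives, in this assay, a 25-fold lower number from compound 1 to compound 4 (1.40 log units; beyond the scatter) and is the first single-place step on this core, which shows that this position is sensitive here too and that this change lowers the number. The earlier step at this position, a 23-fold higher number from compound 2 to compound 3 (1.36 log units; beyond the scatter), lay on a different core and involved other groups, so only the new step ties a large change to the core of compound 1 and to these two groups. The change removes both oxygen atoms and brings in fluorine and chlorine, but no measurement is available to explain the step or to assign it to any one of these differences.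

The compounds shown leave open whether chlorine, fluorine or the pair carries the step, and a plain phenyl or a phenyl bearing a single chlorine, a nitrile or an amine on the same core would help to separate these. Going by these compounds alone, they also leave open whether 3-chloro-4-fluorophenyl gives a step of similar size on the core of compound 2, since no measured pair separates the core from the amide group.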